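Halogen swap on a shared core and compound 4

This account rests on a few compounds, and the source may have more. Where it says the series, first, only, none or still open, it means among the compounds named here.

Compound 1 `CC[C@H](C)[C@H]1C(=O)N[C@H](Cc2cc(Cl)c(O)c(Cl)c2)C(=O)N[C@@H](C(C)C)C(=O)O[C@H](c2ccccc2)[C@H](C)/C=C/C=C(\C)[C@H](OC)C[C@@H]2O[C@@]2(C)C(=O)N1C` and compound 2 `CC[C@H](C)[C@H]1C(=O)N[C@H](Cc2ccc(O)c(Br)c2)C(=O)N[C@@H](C(C)C)C(=O)O[C@H](c2ccccc2)[C@H](C)/C=C/C=C(\C)[C@H](OC)C[C@@H]2O[C@@]2(C)C(=O)N1C` share one core and differ only by 3,5-dichloro-4-hydroxyphenyl in place of 3-bromo-4-hydroxyphenyl on a saturated chain carbon bound to a saturated ring carbon. In a functional assay on PANC-1 cells (Homo sapiens) for antiproliferative activity (a higher number here means a weaker inhibitor, a lower number a stronger inhibitor), compound 1 gives 15.5 nM and compound 2 gives 15.7 nM, so the step of a 1.0-fold lower number from compound 2 to compound 1 (0.01 log units; within the scatter) is small. Compound 3 `CC[C@H](C)[C@H]1C(=O)N[C@H](Cc2ccc(O)c(Br)c2)C(=O)N[C@@H](C(C)(C)O)C(=O)O[C@H](c2ccccc2)[C@H](C)/C=C/C=C(\C)[C@H](OC)C[C@H]2O[C@]2(C)C(=O)N1C` carries a different core; how its core differs from that of compound 2 is not broken down here. In this assay compound 3 gives only a limit, > 200 nM, and the limit of > 200 nM in this assay, at which 1 of the 3 values shown sits, shows where that limit sits. Compound 4 `CC[C@H](C)[C@H]1C(=O)N[C@H](Cc2cc(Cl)c(O)c(Cl)c2)C(=O)N[C@@H](C(C)(C)O)C(=O)O[C@H](c2ccccc2)[C@H](C)/C=C/C=C(\C)[C@H](OC)C[C@H]2O[C@]2(C)C(=O)N1C` is compound 3 with the same change, (3,5-dichloro-4-hydroxyphenyl in place of 3-bromo-4-hydroxyphenyl on a saturated chain carbon bound to a saturated ring carbon), at the same place. The step that the limit leaves unreadable from compound 3 to compound 4 is expected to stay small because a 1.0-fold lower number from compound 2 to compound 1 (0.01 log units; within the scatter) is itself small. Compound 4 is therefore estimated at 400 nM, most likely reported as a limit again.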

Compound 4, half-maximal inhibitory concentration: > 200 nM
Compound 4 ended at the assay's limit (the forecaster's own chance of this, stated with the estimate: 75%); the middle value is on the limit's open side.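

Compound 3 and compound 4 both sit at a limit of the assay, not at a number, so no step between them can be read: the limit of > 200 nM in this assay, at which 2 of the 4 values shown sit.

From the compounds shown here alone, what stays open is whether 3,5-dichloro-4-hydroxyphenyl in place of 3-bromo-4-hydroxyphenyl changes activity at all on the core of compound 3.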